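A Second Methoxy Group and Cell Toxicity

This account rests on a few compounds, and the source may have more. Where it says the series, first, only, none or still open, it means among the compounds named here.

Compound 1, `COc1ccc(-c2cc(/C=C/C(=O)c3ccc(N)cc3)[nH]n2)cc1`, is one of two compounds tested in a functional assay on SR cells (Homo sapiens) for inhibition, read by sulforhodamine B assay, with a stated time of 48 h; on this read-out lower numbers stand for higher toxicity in this test and higher numbers for lower toxicity in this test. In this assay, going by the values given here, compound 1 gives 60100 nM, the only plain number among the two results. The other result belongs to compound 2, `COc1cc(-c2cc(/C=C/C(=O)c3ccc(F)c(F)c3)[nH]n2)cc(OC)c1OC`. For compound 2 this assay returns only a limit, > 100000 nM, not a number. Thus the limit of > 100000 nM in this assay, at which 1 of the 2 values shown sits, is the one further piece of evidence beyond compound 1 itself. Compound 3, `COc1ccc(-c2cc(/C=C/C(=O)c3ccc(N)cc3)[nH]n2)cc1OC`, has not yet been tested. It differs from compound 1 in a single place: methoxy in place of hydrogen on an aromatic carbon, at a position ortho to a methoxy group that is already present. Among the compounds with values here, no measured pair shows this exact change, so the size of the step is open. Compound 2 also carries several methoxy groups, but it differs from compound 1 in more than one place, so only its limit can be noted. The expected change from compound 1 to compound 3 is small, a 1.2-fold higher number from compound 1 to compound 3 (0.07 log units; within the scatter), within the usual scatter or slightly toward lower toxicity. Compound 3 is therefore estimated at 70000 nM, with a likely range from 30000 nM to 150000 nM.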

Compound 3, concentration lethal to 50% of the cells: > 100000 nM
Compound 3: no number, only a limit (the forecaster's own chance of this, stated with the estimate: 30%); at least 1.4-fold (0.15 log units) between middle value and limit.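

The new result gives this position its first reading: methoxy in place of hydrogen on an aromatic carbon, ortho to a methoxy group, produces an at least 1.6-fold higher number from compound 1 to compound 3 (0.22 log units; that floor lies within the scatter) in this assay. Compound 3 returns a limit and not a number, so this step has only a floor, and how far the true value lies past that floor cannot be told. The added methoxy therefore gives no sign of higher toxicity in this test, and most of the results now sit at the same limit: the limit of > 100000 nM in this assay, at which 2 of the 3 values shown sit.

The compounds shown leave open whether a different group at this position, such as a hydroxyl, a fluorine or the longer ethoxy chain, would give a lower number than compound 1 or also end at the limit. From the compounds shown here alone, it is equally open whether the same methoxy step would look alike on a compound carrying a nitrile in place of the amine.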